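Replacing a 4-chlorocyclohexyl group with an all-carbon group

The compounds below may be only part of what the source reports. "The series", "measured", "known", "first", "only" and "open" are said of these compounds alone.

Going by the values given here, in an ADME assay for protein binding, using equilibrium dialysis, at pH 7.4, tested at 2 uM (a higher number here means a larger unbound share of the compound, a lower number a smaller unbound share), compound 2 `CC(C)N(c1cc(C#CC(C)(C)C)sc1C(=O)O)C(=O)[C@H]1CC[C@H](Cl)CC1` gives 0.14, the higher of the two numbers measured so far. Among the compounds with values here, the only other measured compound, compound 1 `CC(C)N(C(=O)[C@H]1[C@@H]2CCCC[C@@H]21)c1cc(C#CC(C)(C)C)sc1C(=O)O`, gives 0.04. Compound 3 `CC(C)N(C(=O)[C@H]1CC[C@@H]2C[C@@H]2CC1)c1cc(C#CC(C)(C)C)sc1C(=O)O` has not yet been measured. It differs from compound 2 in one place, on a carbonyl carbon: a group of 8 heavy atoms (8 carbon; one three-membered non-aromatic ring of carbon only, one seven-membered non-aromatic ring of carbon only) in place of a group of 7 heavy atoms (6 carbon, 1 chlorine; one six-membered non-aromatic ring of carbon only), on a carbonyl carbon.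

Within the data shown here, one measured step bears on this change: a 3.5-fold higher number from compound 1 to compound 2 (0.54 log units; beyond the scatter), a modest step beyond the scatter. There, a group of carbon only, holding a three-membered ring, gave way to the 4-chlorocyclohexyl group. The change to compound 3 goes the other way. The entering group again has only carbon and a three-membered ring, although its second ring is seven-membered rather than six-membered. Among the measured compounds shown here, a single step is thin evidence, and no measured compound carries this exact group. Even so, a fall in this assay of similar modest size is expected. The estimated step is a 2.8-fold lower number from compound 2 to compound 3 (0.45 log units; beyond the scatter). For compound 3, the expected value is 0.05, with an estimated range of 0.02 to 0.12.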

Compound 3, unbound fraction: 0.08
Estimate against measurement, compound 3: 1.6-fold (0.20 log units) below; measured number inside the range.
By their numbers in this assay, from the lowest: compounds 1, 3 and 2 (each within the scatter of the next, the first and the last beyond it).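

In this assay, replacing the 4-chlorocyclohexyl group with the all-carbon group holding a three-membered and a seven-membered ring gives a 1.8-fold lower number from compound 2 to compound 3 (0.24 log units; within the scatter), so on this carbonyl carbon the swap cannot be told apart from the spread of repeat measurements. Going from a six-membered to a seven-membered second ring in the all-carbon group gives a 2.0-fold higher number from compound 1 to compound 3 (0.30 log units; within the scatter), which likewise cannot be told apart from that spread. Compound 3 therefore sides clearly with neither of the other two compounds, and the only clear gap at this position remains a 3.5-fold higher number from compound 1 to compound 2 (0.54 log units; beyond the scatter), but nothing available here accounts for any of these numbers.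

The compounds shown leave open whether the chlorine or the rest of the group matters more, since a plain cyclohexyl group on the same carbonyl carbon would be needed to separate the two. Also open, from the compounds shown here alone, is how a group carrying an oxygen or nitrogen atom, such as a 4-hydroxycyclohexyl or a piperidine ring, would read in this assay at this place on the shared core.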